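Aryl change at the azidoquinazoline series, third member

The compounds below may be only part of what the source reports. "The series", "measured", "known", "first", "only" and "open" are said of these compounds alone.

Compound 1 `COc1cc2nc(-c3cccc(Cl)c3)nc(N=[N+]=[N-])c2cc1OC` and compound 2 `COc1ccc(-c2nc(N=[N+]=[N-])c3cc(OC)c(OC)cc3n2)cc1` share a core carrying an azido group and differ only in the aryl group attached on the aromatic carbon between two ring nitrogen atoms. In a functional assay on HCT-116 cells (Homo sapiens) for cytotoxicity, read by MTT assay, with a stated time of 72 h (a lower number here means a stronger inhibitor, a higher number a weaker inhibitor), compound 1 gives 10000 nM and compound 2 gives 10000 nM. The step of no change at the digits printed from compound 1 to compound 2 (within the scatter) shows that exchanging the aryl group did nothing here that the scatter would not cover. Compound 2 thus stands level with compound 1 on the numbers shown, and nothing in these two points separates one aryl group from the other.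

Compound 3 `COc1cc2nc(-c3cccc(C)c3)nc(N=[N+]=[N-])c2cc1OC` is the next variation: 3-methylphenyl in place of 4-methoxyphenyl on an aromatic carbon. Within the data shown here, the only measured step that bears on this change is the aryl exchange from compound 1 to compound 2, which was flat in this assay. An aryl exchange of similar kind is therefore not expected to move the read-out beyond the scatter, and the expected step of no change at the digits printed from compound 2 to compound 3 (within the scatter) is no change. Compound 3 is estimated at 10000 nM in this assay, with a range from 5000 nM to 20000 nM.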

Compound 3, half-maximal inhibitory concentration: 9000 nM
Compound 3: the middle estimate sits 1.1-fold (0.05 log units) above what was measured; low and high end bracket the measured number.
By their numbers in this assay, from the lowest: compounds 3, 1 and 2 (each within the scatter of the next).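

In this assay, 3-methylphenyl in place of 4-methoxyphenyl on the aromatic carbon between two ring nitrogen atoms gives a 1.1-fold lower number from compound 2 to compound 3 (0.05 log units; within the scatter), so a third aryl group at this position also leaves the read-out within the scatter, even though the hydrogen-bond acceptor counted in 4-methoxyphenyl is absent from 3-methylphenyl. The pair of compound 1 and compound 3 narrows the comparison to a single substituent on the aryl group, and methyl in place of chloro gives a 1.1-fold lower number from compound 1 to compound 3 (0.05 log units; within the scatter), so among these compounds neither this substituent exchange nor the wider aryl exchanges separate one compound from another. No independent data bear on why these aryl groups read alike.

Among these compounds, with no step among the three compounds beyond the scatter, the series gives no basis for ranking them or for assigning a preferred aryl group at this position. On these data alone, it remains open whether a carboxylic acid or a dimethylamino group on the aryl ring, a butyl chain in place of the aryl group, or an amine in place of the azido group would move the read-out.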